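Moving the Chlorine on a Benzylsulfanyl Group

This account rests on a few compounds, and the source may have more. Where it says the series, first, only, none or still open, it means among the compounds named here.

The measured compounds and their values:
Compound 1, `CC1=C(C(=O)Nc2ccc(F)cc2)C(c2ccc([N+](=O)[O-])cc2)N=C(SCc2cccc(Cl)c2)N1`, gives 2.1%.
Compound 2, `CC1=C(C(=O)Nc2ccc(F)cc2)C(c2ccc([N+](=O)[O-])cc2)N=C(SCc2ccc(Cl)cc2)N1`, gives 3.6%.
Compound 3, `CC1=C(C(=O)Nc2ccc([N+](=O)[O-])cc2)C(c2ccc(Br)cc2)N=C(SCc2cccc(Cl)c2)N1`, gives 2.1%.

All three were tested in a functional assay on the whole organism (artery, strain albino) with Rattus norvegicus as the target, with a stated time of 15 min, at a dose of 10 mg/kg by the oral route; a lower number here means less inhibition, a higher number more inhibition at the dose given (going by the name of the read-out). Compound 1 and compound 2 share one core and differ in a single place: 4-chlorophenyl in place of 3-chlorophenyl on a saturated chain carbon bound to a sulfur. That change gave a step of a number 1.5 percentage points higher from compound 1 to compound 2 (within the scatter). Compound 3 carries a different core; the difference between the two cores is not broken down here. Compound 3 and compound 1 read the same at the digits shown, and together they are the lowest of the three numbers, while compound 2 stands only slightly apart from them, all inside the ordinary scatter.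

Compound 4, `CC1=C(C(=O)Nc2ccc([N+](=O)[O-])cc2)C(c2ccc(Br)cc2)N=C(SCc2ccc(Cl)cc2)N1`, has not yet been measured. It relates to compound 3 exactly as compound 2 relates to compound 1: 4-chlorophenyl in place of 3-chlorophenyl on a saturated chain carbon bound to a sulfur. The surroundings of the change are the same in both pairs, so this is the same change made on the core of compound 3.

Within the data shown here, the only guide to what this change does is the pair already measured. Because that pair moved by a number 1.5 percentage points higher from compound 1 to compound 2 (within the scatter), a step of about that size is expected again. Compound 4 is therefore expected to give 3.5%, with a likely range from 0% to 12%. Among the measured compounds shown here, the expected step is a number 1.4 percentage points higher from compound 3 to compound 4 (within the scatter), which rests on the single earlier pair and could easily be swallowed by the scatter.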

Compound 4, a percentage reported as inhibition, in the whole organism at one dose (the size of the read-out at that dose, not a potency): 3.1%
Estimate against measurement, compound 4: 0.4 percentage points above; the measured number falls inside the stated range.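

In this assay, putting 4-chlorophenyl in place of 3-chlorophenyl on the core of compound 3 gives a number 1 percentage points higher from compound 3 to compound 4 (within the scatter). Set beside the same change on the core of compound 1, the two results agree: the same change on two cores in this assay, a number 1.5 percentage points higher (within the scatter) from compound 1 to compound 2 and a number 1 percentage points higher (within the scatter) from compound 3 to compound 4, 0.5 percentage points apart, within the scatter of two such steps. This shows that, on these two cores, the change behaves alike as far as the read-out can tell, and that swapping the core did not produce a visibly different outcome; it does not show that moving the chlorine has any real effect, since each step on its own is no larger than repeated measurements of the same compound could produce, and two pairs say nothing firm about any further core.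

The compounds shown keep a chlorine-bearing benzyl group on the sulfur throughout, so it remains open whether an amine or a carboxylic acid on that ring in place of the chlorine, or a longer chain in place of the benzyl group, would move the inhibition beyond the scatter. Also open, from the compounds shown here alone, is whether the two chlorine placements would separate at all at a different dose, as every number here comes from a single dose.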